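The source may hold more compounds than are shown below. What is called first, only, known or untested is meant among the compounds shown, and "the series" means these compounds.

Measured compounds:
compound 1, `CC(C)c1onc(-c2ccccc2)c1COc1ccc(CCCC(=O)O)cc1` — 31000 nM
compound 2, `CC(C)c1onc(-c2ccccc2)c1COc1ccc(CCCCC(=O)O)cc1` — a limit, > 30000 nM
compound 3, `CC(C)c1onc(-c2ccccc2)c1COc1ccc(COc2ccc(C(=O)O)cc2)cc1` — 2300 nM

In an assay on HEK-293T cells for activation of Bile acid receptor (Homo sapiens), read by a luciferase reporter, with a stated time of 14 h (on this read-out higher numbers stand for an effect only at larger amounts of compound and lower numbers for an effect already at smaller amounts), compound 1 gives 31000 nM, the higher of the two numbers obtained; the nearest compound, compound 3, shows a 13-fold lower number from compound 1 to compound 3 (1.13 log units; beyond the scatter). Compound 2 does not yield a number in this assay but only a limit, (the limit of > 30000 nM in this assay, at which 1 of the 3 values shown sits). From compound 2 the same tail change gives an at least 13-fold lower number from compound 2 to compound 3 (1.11 log units; beyond the scatter), while the step from compound 1 to compound 2 is a step that the limit leaves unreadable from compound 1 to compound 2.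

Compound 4, `CC(C)c1onc(-c2c(Cl)cccc2Cl)c1COc1ccc(CCCC(=O)O)cc1`, differs from compound 1 in one place: 2,6-dichlorophenyl in place of phenyl on an aromatic carbon. All three measured steps concern the acid-bearing chain on the other end of the shared core, so none of them bears on a change at the phenyl. Among the measured compounds shown here, with no measured step to read from, the expected step in this assay is none beyond the scatter, and compound 4 is estimated at 18000 nM, within the range 5000 nM to 50000 nM, meaning an expected step of a 1.7-fold lower number from compound 1 to compound 4 (0.24 log units; within the scatter).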

Compound 4, half-maximal effective concentration: 6000 nM
Compound 4: the middle estimate sits 3.0-fold (0.48 log units) above what was measured; measured number inside the range.
By their numbers in this assay, from the lowest: compound 3; then compound 4; then compound 1.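

The aromatic group on the shared core, a phenyl in compound 1, compound 2 and compound 3, proves able to move the read-out in this assay: with 2,6-dichlorophenyl in its place, the result is a 5.2-fold lower number from compound 1 to compound 4 (0.71 log units; beyond the scatter). The acid-bearing chain is therefore not the only part of the shared core at which a single change goes beyond the scatter, since this position, on an aromatic carbon next to the ring nitrogen, responds as well. Nothing at hand gives a reason for this step.

As far as these compounds go, whether a single chlorine, or methyl or methoxy groups in place of the chlorine atoms, would give a similar step remains open. So does whether 2,6-dichlorophenyl would have a similar effect alongside the 4-carboxyphenoxy tail of compound 3.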